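Cyano to (isobutylcarbonyl)oxy on the core of compound 1

This account rests on a few compounds, and the source may have more. Where it says the series, first, only, none or still open, it means among the compounds named here.

Compound 1 `C[S+]([O-])/C=C/c1cc(=O)c2cc(C#N)ccc2o1` is the parent of this small set. In a functional assay on DLD-1 cells (Homo sapiens) for cytotoxicity, with a stated time of 48 h (a lower number here means a stronger inhibitor, a higher number a weaker inhibitor), compound 1 gives > 10000 nM, which is a limit of the assay rather than a number, so compound 1 sits at the limit of > 10000 nM in this assay, at which 1 of the 3 values shown sits. Compound 2 `CC(C)Oc1ccc2oc(/C=C/[S+](C)[O-])cc(=O)c2c1` gives 8000 nM in this assay, and compound 3 `CCCCOc1ccc2oc(/C=C/[S+](C)[O-])cc(=O)c2c1` gives 4800 nM. The steps of an at least 1.2-fold lower number from compound 1 to compound 2 (0.09 log units; that floor lies within the scatter) and an at least 2.0-fold lower number from compound 1 to compound 3 (0.31 log units; beyond the scatter) replace cyano by isopropoxy or butoxy on an aromatic carbon, while a 1.7-fold lower number from compound 2 to compound 3 (0.22 log units; within the scatter) stays within the scatter. Compound 4 `CC(C)CC(=O)Oc1ccc2oc(/C=C/[S+](C)[O-])cc(=O)c2c1` carries the change ((isobutylcarbonyl)oxy in place of cyano on an aromatic carbon). Because an at least 2.0-fold lower number from compound 1 to compound 3 (0.31 log units; beyond the scatter) lies beyond the scatter whereas an at least 1.2-fold lower number from compound 1 to compound 2 (0.09 log units; that floor lies within the scatter) need not, a modest step in the same direction is expected for compound 4 in this assay. Compound 4 is estimated at 6000 nM, between 2500 nM and 15000 nM. The expected step is an at least 1.6-fold lower number from compound 1 to compound 4 (0.22 log units; that floor lies within the scatter).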

Compound 4, half-maximal inhibitory concentration: 6100 nM
The estimate for compound 4 lay 1.0-fold (0.01 log units) below the measured number, and the stated range covers the measured number.
By their numbers in this assay, from the lowest: compounds 3, 4 and 2 (each within the scatter of the next). At a limit, above all of these: compound 1.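

In this assay, isobutylcarbonyl on the oxygen reads the same as butyl or isopropyl there, with a 1.3-fold higher number from compound 3 to compound 4 (0.10 log units; within the scatter) and a 1.3-fold lower number from compound 2 to compound 4 (0.12 log units; within the scatter). So the carbonyl-bearing group joins the two alkyl groups on this aromatic carbon with no separation from either, while the step on replacing cyano, an at least 1.6-fold lower number from compound 1 to compound 4 (0.21 log units; that floor lies within the scatter), does not by itself clear the scatter. Compound 1 is held at a limit, not a number: the limit of > 10000 nM in this assay, at which 1 of the 4 values shown sits.

As far as these compounds go, whether an amine or a carboxylic acid on this aromatic carbon would separate from these oxygen-linked groups stays open. From the compounds shown here alone, whether a longer chain on the oxygen would move the number beyond the scatter also stays open.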